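The source may hold more compounds than are shown below. What is called first, only, known or untested is meant among the compounds shown, and "the series" means these compounds.

Measured compounds in a functional assay on DLA cells (Mus musculus) for cytotoxicity, read by trypan blue exclusion, with a stated time of 48 h; on this read-out higher numbers stand for weaker inhibition and lower numbers for stronger inhibition:
compound 1 `Cc1cc(C(=O)c2ccccc2)ccc1OCC(=O)Nc1nc(-c2ccccc2)cs1` gives 21500 nM
compound 2 `COc1ccc(-c2csc(NC(=O)COc3ccc(C(=O)c4ccccc4)cc3C)n2)cc1` gives 24200 nM
compound 3 `Cc1ccc(C(=O)c2ccc(OCC(=O)Nc3nc(-c4ccccc4)cs3)c(C)c2)cc1` gives 25000 nM

Compound 3 stands within the scatter of both other members of the series: the pair compound 1 and compound 3 differ by a 1.2-fold higher number from compound 1 to compound 3 (0.07 log units; within the scatter), and the numbers for compound 3 and compound 2 lie within the scatter of each other. Compound 4 `COc1ccc(-c2csc(NC(=O)COc3ccc(C(=O)c4ccc(C)cc4)cc3C)n2)cc1` has not been measured in this assay. It differs from compound 3 by methoxy in place of hydrogen on an aromatic carbon.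

Within the data shown here, one measured step bears directly on this change: the same substitution, methoxy in place of hydrogen on an aromatic carbon, taken from compound 1 to compound 2 gave a 1.1-fold higher number from compound 1 to compound 2 (0.05 log units; within the scatter). That step sat within the scatter, and the other step in the series, a 1.2-fold higher number from compound 1 to compound 3 (0.07 log units; within the scatter), did the same. No step beyond the scatter is therefore expected in this assay for the change from compound 3 to compound 4; the expected step is a 1.0-fold higher number from compound 3 to compound 4 (0.02 log units; within the scatter). The estimate for compound 4 in this assay is 26000 nM, expected to fall between 15000 nM and 45000 nM.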

Compound 4, half-maximal inhibitory concentration: 16000 nM
For compound 4 the middle estimate is 1.6-fold (0.21 log units) above the measured one, and the stated range covers the measured number.
By their numbers in this assay, from the lowest: compounds 4, 1, 2 and 3 (each within the scatter of the next).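

In this assay, methoxy on an aromatic carbon, para to a large group, now has a second reading, a 1.6-fold lower number from compound 3 to compound 4 (0.19 log units; within the scatter), and methyl on an aromatic carbon also has a second reading, a 1.5-fold lower number from compound 2 to compound 4 (0.18 log units; within the scatter). The phenyl to 4-methoxyphenyl change therefore gives no step beyond the scatter on either core, and its two readings agree within the scatter: the same change on two cores in this assay, a 1.1-fold higher number (0.05 log units; within the scatter) from compound 1 to compound 2 and a 1.6-fold lower number (0.19 log units; within the scatter) from compound 3 to compound 4, 1.8-fold (0.25 log units) apart, within the scatter of two such steps. The methyl change likewise stays within the scatter on both cores, with its two readings in agreement: the same change on two cores in this assay, a 1.2-fold higher number (0.07 log units; within the scatter) from compound 1 to compound 3 and a 1.5-fold lower number (0.18 log units; within the scatter) from compound 2 to compound 4, 1.8-fold (0.25 log units) apart, within the scatter of two such steps.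

On these data alone, whether an amine, a carboxylic acid or a longer alkoxy chain in place of methoxy at this position would give a step beyond the scatter remains open. As far as these compounds go, it is also open whether any group at this position can separate compounds at all.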